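A Sec-Butyl Step Starting from a Limit

The compounds below may be only part of what the source reports. "The series", "measured", "known", "first", "only" and "open" are said of these compounds alone.

- Compound 1 `CC(C)[C@@H](NC(=O)OC(C)(C)C)C(=O)Nc1ccc2ncnc(Nc3cccc(Br)c3)c2c1`: > 50000 nM (a limit)
- Compound 2 `CC(C)(C)OC(=O)NCC(=O)Nc1ccc2ncnc(Nc3cccc(C(F)(F)F)c3)c2c1`: > 50000 nM (a limit)

The starting point for this step was measured in a functional assay on HepG2 cells (Homo sapiens) for antiproliferative activity, read by sulforhodamine B assay, with a stated time of 72 h; on this read-out higher numbers stand for weaker inhibition and lower numbers for stronger inhibition. There, compound 2 gives > 50000 nM, which is a limit and not a number. It has company at that mark, since the data show (the limit of > 50000 nM in this assay, at which 2 of the 2 values shown sit). Among the measured compounds shown here, no numerical value is therefore available for either measured compound, and no step between them can be read.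

Compound 3 `CC[C@H](C)[C@@H](NC(=O)OC(C)(C)C)C(=O)Nc1ccc2ncnc(Nc3cccc(C(F)(F)F)c3)c2c1` is compound 2 altered in one place: sec-butyl in place of hydrogen on a saturated chain carbon bound to an amide-type nitrogen and a carbonyl carbon. A sec-butyl stands in place of hydrogen on a saturated chain carbon bound to an amide-type nitrogen and a carbonyl carbon.

For the measured compounds named here, with no measured step to draw on, the expectation in this assay is of no change beyond the scatter and no clear direction. It rests on compound 1, whose > 50000 nM is also a limit. The estimated step of an at least 1.1-fold lower number from compound 2 to compound 3 (0.04 log units; that floor lies within the scatter) is expected to be small, and a further limit is the likeliest report. For compound 3 the expected value is 45000 nM, with an estimated range from 15000 nM to 100000 nM.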

Compound 3, half-maximal inhibitory concentration: > 50000 nM
Compound 3 was reported as a limit; the forecaster's own chance of this, stated with the estimate: 70%; at least 1.1-fold (0.04 log units) between middle value and limit.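

In this assay compound 3 gives > 50000 nM, which is a limit. Among the compounds shown here, compound 2 also stands at a limit, so no step between compound 2 and compound 3 can be read: the limit of > 50000 nM in this assay, at which 3 of the 3 values shown sit. The compounds shown leave open whether sec-butyl in place of hydrogen changes the activity at all, since none of them has a numerical value.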